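This account rests on a few compounds, and the source may have more. Where it says the series, first, only, none or still open, it means among the compounds named here.

Measured compounds in an ADME assay on microsomes from liver (Rattus norvegicus) for metabolic stability, read by LC-MS, tested at 1 mM; a higher number here means that the compound lasts longer, a lower number that the compound disappears faster:
- compound 1 `N#Cc1ccc(F)cc1Cn1c(N2CCC[C@@H](N)C2)nc2c(-c3ccc(F)cc3)c[nH]c2c1=O`: 1.21 h
- compound 2 `CS(=O)(=O)c1ccc(-c2c[nH]c3c(=O)n(Cc4cc(F)ccc4C#N)c(N4CCC[C@@H](N)C4)nc23)cc1F`: 2.78 h

Compound 2 stands highest of the two numbers in this assay; its nearest neighbour is compound 1, and the gap between them, a 2.3-fold higher number from compound 1 to compound 2 (0.36 log units; beyond the scatter), lies beyond the scatter. The next compound, compound 3 `N#Cc1ccc(F)cc1Cn1c(N2CCC[C@@H](N)C2)nc2c(-c3ccsc3)c[nH]c2c1=O`, is not yet measured. Its change from compound 2 is thiophen-3-yl in place of 3-fluoro-4-(methylsulfonyl)phenyl on an aromatic carbon.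

For the measured compounds named here, only one measured step bears on this change: a 2.3-fold higher number from compound 1 to compound 2 (0.36 log units; beyond the scatter), where the 3-fluoro-4-(methylsulfonyl)phenyl group entered in place of 4-fluorophenyl. Going by the values given here, compound 3 removes that same 3-fluoro-4-(methylsulfonyl)phenyl group again, so a step back of about that size in the opposite direction is expected, a 2.5-fold lower number from compound 2 to compound 3 (0.40 log units; beyond the scatter), with no measured pair showing what thiophen-3-yl itself does. Compound 3 is therefore estimated at 1.1 h, within a range of 0.5 h to 2.4 h.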

Compound 3, half-life: 0.783 h
Compound 3: the middle estimate sits 1.4-fold (0.15 log units) above what was measured; the range from low to high includes it.
By their numbers in this assay, from the lowest: compounds 3 and 1 (each within the scatter of the next); then compound 2.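

In this assay thiophen-3-yl on this aromatic carbon of the five-membered ring gives a 3.6-fold lower number from compound 2 to compound 3 (0.55 log units; beyond the scatter) and so does not keep what 3-fluoro-4-(methylsulfonyl)phenyl gave. Against 4-fluorophenyl the same group gives a 1.5-fold lower number from compound 1 to compound 3 (0.19 log units; within the scatter) and the two cannot be told apart, so among the three groups at this place only 3-fluoro-4-(methylsulfonyl)phenyl stands apart, with both of its steps beyond the scatter. Nothing measured here accounts for these differences.

Still open, going by these compounds, is whether the methylsulfonyl group carries the step by itself or only together with the fluorine on the same phenyl ring. Also open, on these data alone, is how a phenyl ring bearing a carboxylic acid or an amine at this place would compare with compound 2 in this assay on the same core.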